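Swapping Methyl for Chloro on a Weak Cell Inhibitor

The compounds below may be only part of what the source reports. "The series", "measured", "known", "first", "only" and "open" are said of these compounds alone.

Measured so far:
- compound 1 `O=C1CSC(N2N=C(c3ccc(Br)cc3)CC2c2ccc3ccccc3c2)=N1`: 4220 nM
- compound 2 `Cc1ccc(C2=NN(C3=NC(=O)CS3)C(c3cccc4ccccc34)C2)cc1`: 3210 nM

Both compounds were tested in a functional assay on HeLa cells (Homo sapiens) for inhibition, read by CCK-8 assay, with a stated time of 48 h; a lower number here means a stronger inhibitor, a higher number a weaker inhibitor. Compound 2 has the lowest of the two numbers, with 3210 nM; the nearest is compound 1 at 4220 nM, and that gap lies within the scatter, so the two cannot be ranked against each other.

Compound 3 `O=C1CSC(N2N=C(c3ccc(Cl)cc3)CC2c2cccc3ccccc23)=N1` has not yet been measured. It differs from compound 2 in a single spot: chloro in place of methyl on an aromatic carbon. Among the compounds with values here, no step between measured compounds is available to show how such a swap behaves here, so the expectation rests on the two values alone.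

With compound 1 and compound 2 sitting within the scatter of each other, compound 3 is expected to stay close to compound 2, with a step of a 1.1-fold higher number from compound 2 to compound 3 (0.04 log units; within the scatter), that is, none beyond the scatter. The estimate for compound 3 is 3500 nM, in a range from 1500 nM to 8000 nM.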

Compound 3, half-maximal inhibitory concentration: 8840 nM
The estimate for compound 3 lay 2.5-fold (0.40 log units) below the measured number, outside the stated range (above it).
By their numbers in this assay, from the lowest: compounds 2 and 1 (each within the scatter of the next); then compound 3.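

In this assay, within the data shown here, the change from 4-methylphenyl to 4-chlorophenyl gives a 2.8-fold higher number from compound 2 to compound 3 (0.44 log units; beyond the scatter) and is the first step here that lies beyond the scatter. This position, on an aromatic carbon para to a large group, therefore responds to the exchange of a single heavy atom, with methyl giving the stronger inhibitor of this pair. No supporting measurement bears on this step, so it stands as an observation without an explanation.

One step cannot show how the number would move with very different groups at this position, such as an amine or a carboxylic acid. It also leaves open whether the same exchange of methyl for chloro would have a similar effect on the core of compound 1.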